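The source may report more compounds than this note shows. Statements on the series, on what has been measured and on what is new or still open speak of the compounds shown alone.

Measured compounds:
- Compound 1 `CC[C@H](N)C(=O)N1CCc2c(C)c3c(n2-c2ccc(C(N)=O)c(c2)N[C@@H](C)[C@H](C)C1)CC(C)(C)CC3=O`: 33 nM
- Compound 2 `Cc1c2c(n3c1CCN(C(=O)C(C)(C)N)C[C@@H](C)[C@H](C)Nc1cc-3ccc1C(N)=O)CC(C)(C)CC2=O`: 25 nM
- Compound 3 `Cc1c2c(n3c1CCN(C(=O)C1(N)CCCC1)C[C@@H](C)[C@H](C)Nc1cc-3ccc1C(N)=O)CC(C)(C)CC2=O`: 27 nM

In a functional assay on HCT-116 cells (Homo sapiens) for antiproliferative activity (a lower number here means a stronger inhibitor, a higher number a weaker inhibitor), compound 3 gives 27 nM, which lies within the usual scatter of the values for the other two compounds, so the three cannot be ranked. The next compound, compound 4 `Cc1c2c(n3c1CCN(C(=O)[C@H](C)O)C[C@@H](C)[C@H](C)Nc1cc-3ccc1C(N)=O)CC(C)(C)CC2=O`, has not yet been measured. Its structural change is 1-hydroxyethyl in place of 1-aminocyclopentyl on a carbonyl carbon.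

Within the data shown here, three measured steps bear on this site: a 1.3-fold lower number from compound 1 to compound 2 (0.12 log units; within the scatter), a 1.2-fold lower number from compound 1 to compound 3 (0.09 log units; within the scatter) and a 1.1-fold higher number from compound 2 to compound 3 (0.03 log units; within the scatter). All three are small, so swapping one of these groups for another has made no clear difference so far. However, each of those groups carries an amino group, and no measured compound shows what 1-hydroxyethyl does here. The expectation is therefore a small change at most, with a slight lean towards a higher number and wide uncertainty.

The estimated change is a 1.5-fold higher number from compound 3 to compound 4 (0.17 log units; within the scatter). For compound 4, the expected value is 40 nM, with an estimated range of 15 nM to 110 nM.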

Compound 4, half-maximal inhibitory concentration in the HCT-116 assay: 42 nM
Beside the measured number, compound 4's estimate is 1.1-fold (0.02 log units) below it; low and high end bracket the measured number.
By their numbers in the HCT-116 assay, from the lowest: compounds 2, 3, 1 and 4 (each within the scatter of the next).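

Swapping the amino-bearing groups on the carbonyl carbon for 1-hydroxyethyl gives, in the HCT-116 assay, a 1.6-fold higher number from compound 3 to compound 4 (0.19 log units; within the scatter), a 1.7-fold higher number from compound 2 to compound 4 (0.23 log units; within the scatter) and a 1.3-fold higher number from compound 1 to compound 4 (0.10 log units; within the scatter), so an amino group at this position is not needed for activity in these cells, where compound 4 gives 42 nM without one. The same swap, which also removes the five-membered carbon ring of 1-aminocyclopentyl, gives in a physicochemical assay for solubility, at pH 7.4 (on this read-out lower numbers stand for lower solubility and higher numbers for higher solubility), a 1.1-fold higher number from compound 3 to compound 4 (0.05 log units; within the scatter), so solubility does not separate this pair either: compound 3 gives 53 ug/mL and compound 4 gives 60 ug/mL on this read-out. No measurement shown here explains why these groups read alike.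

From the compounds shown here alone, all four groups carry either an amino or a hydroxyl group, so it remains open whether a plain ethyl group on the carbonyl carbon, with neither, would keep this activity. A carboxylic acid at the same place, and the opposite stereocentre of 1-hydroxyethyl, also remain untested by the compounds shown.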